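The source may hold more compounds than are shown below. What is called first, only, known or untested is meant among the compounds shown, and "the series" means these compounds.

Compound 1 `COc1cc(OC)c(OC)cc1/C=C/COC(=O)/C=C/c1ccc(Br)cc1`: 105 mg/kg
Compound 2 `COc1cc(OC)c(OC)cc1/C=C/COC(=O)/C=C/c1cc(OC)c(OC)c(OC)c1`: 85.5 mg/kg
Compound 3 `COc1cc(OC)c(OC)cc1/C=C/COC(=O)/C=C/c1ccc(OC)c(OC)c1OC`: 78.4 mg/kg

In a functional assay on the whole organism (strain Kunming) with Mus musculus as the target, in the formalin test, with a stated time of 0.5 h (a lower number here means that less compound is needed, a higher number that more compound is needed for the effect), compound 1 at 105 mg/kg lies within the scatter of both compound 2 and compound 3, so the three numbers do not separate. Compound 4 `COc1cc(OC)c(OC)cc1/C=C/COC(=O)/C=C/c1ccccc1Cl` keeps the shared core and differs from compound 1 at one place: 2-chlorophenyl stands in place of 4-bromophenyl on a double-bonded chain carbon bound to a double-bonded chain carbon (2-chlorophenyl in place of 4-bromophenyl on a double-bonded chain carbon bound to a double-bonded chain carbon). Among the compounds with values here, no measured pair shows this exchange alone, so no change beyond the scatter is expected in this assay on this basis. The expected outcome is a step of a 1.1-fold lower number from compound 1 to compound 4 (0.04 log units; within the scatter) that stays within the scatter. The estimate for compound 4 is 95 mg/kg (expected range 55 mg/kg to 165 mg/kg).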

Compound 4, dose for half-maximal effect: 101 mg/kg
Beside the measured number, compound 4's estimate is 1.1-fold (0.03 log units) below it; measured number inside the range.
By their numbers in this assay, from the lowest: compounds 3, 2, 4 and 1 (each within the scatter of the next).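

In this assay, within the data shown here, 2-chlorophenyl in place of 4-bromophenyl on a double-bonded chain carbon bound to a double-bonded chain carbon gives a 1.0-fold lower number from compound 1 to compound 4 (0.02 log units; within the scatter) and provides the first pair that differs in one place. At this place, this exchange leaves the number within the scatter, although the halogen and its ring location change together. No measured evidence bears on this result.

Going by these compounds, whether an amine or a carboxylic acid on this phenyl ring would move the number beyond the scatter stays open. The halogen and its ring location also remain unseparated.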